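Methyl on the Chain: Carrying One Step Across

A few compounds are considered here, and "the series" means these few. Any claim that something is new, unique, unknown or untested is made for them only; others in the source may bear on it.

Compound 1 `CN1C(=O)N(C)C2C1NC(=S)N2/N=C/C=C/c1ccccc1` and compound 2 `CC(/C=N/N1C(=S)NC2C1N(C)C(=O)N2C)=C\c1ccccc1` share one core, while compound 3 `CCN1C(=O)N(CC)C2C1NC(=S)N2/N=C/C=C/c1ccccc1` and compound 4 `CCN1C(=O)N(CC)C2C1NC(=S)N2/N=C/C(C)=C/c1ccccc1` share another; how the core of compound 3 differs from that of compound 1 is not broken down here. In a functional assay on A549 cells (Homo sapiens) for inhibition, read by MTT assay, with a stated time of 72 h (a lower number here means a stronger inhibitor, a higher number a weaker inhibitor), compound 1 gives 45700 nM, and compound 2 gives 49400 nM. The change between them, (methyl in place of hydrogen on a double-bonded chain carbon bound to a carbon with a double bond to nitrogen and a double-bonded chain carbon), made a step of a 1.1-fold higher number from compound 1 to compound 2 (0.03 log units; within the scatter). Compound 3 stands apart from both: in this assay compound 3 gives 6530 nM, a number beyond the scatter from compound 1 and from compound 2 alike, and the lowest of the three. Compound 4 carries the same change onto the core of compound 3, (methyl in place of hydrogen on a double-bonded chain carbon bound to a carbon with a double bond to nitrogen and a double-bonded chain carbon), and the two places read the same word for word. Because the earlier step of a 1.1-fold higher number from compound 1 to compound 2 (0.03 log units; within the scatter) stayed within the scatter, a step of a 1.1-fold higher number from compound 3 to compound 4 (0.03 log units; within the scatter) is expected here, that is, hardly any change. Going by the values given here, with only a single earlier pair to lean on, the expectation is a loose one. Compound 4 is therefore estimated at 7000 nM, with a range from 3000 nM to 16000 nM.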

Compound 4, half-maximal inhibitory concentration: > 100000 nM
Compound 4: a limit, no number; the forecaster's own chance of this, stated with the estimate: 5%; middle value at least 14-fold (1.15 log units) from the limit.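

On the second core, methyl in place of hydrogen gave an at least 15-fold higher number from compound 3 to compound 4 (1.18 log units; beyond the scatter) in this assay. Set beside the earlier step of a 1.1-fold higher number from compound 1 to compound 2 (0.03 log units; within the scatter), this shows that the change did not carry from one core to the other, so a result on one core was no guide to the other in this series: the same change on two cores in this assay, a 1.1-fold higher number (0.03 log units; within the scatter) from compound 1 to compound 2 and an at least 15-fold higher number (1.18 log units; beyond the scatter) from compound 3 to compound 4, at least 14-fold (1.15 log units) apart, beyond the scatter of two such steps. In this assay compound 4 gives > 100000 nM, which is a limit and not a number, and the data show neither the full size of the step nor why the two cores read so differently: the limit of > 100000 nM in this assay, at which 1 of the 4 values shown sits.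

With a single pair on each core, the compounds shown leave open whether the gap between the two cores holds for any other change on the chain. They also leave open how an ethyl group or a chlorine atom in the same place would read on either core.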